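The compounds below may be only part of what the source reports. "The series", "measured", "known", "first", "only" and "open" are said of these compounds alone.

The measured compounds in a functional assay on HT-29 cells (Homo sapiens) for cytotoxicity, read by MTT assay, with a stated time of 72 h (a higher number here means a weaker inhibitor, a lower number a stronger inhibitor), are:

Compound 1, `COc1ccc(/C=N/NC(=O)Nc2ccc(Oc3ccnc(-c4nncn4CCN(C)C)c3)c(F)c2)c(OC)c1`, which gives 1780 nM
Compound 2, `CN(C)CCn1cnnc1-c1cc(Oc2ccc(NC(=O)N/N=C/c3ccc(O)c(Br)c3)cc2F)ccn1`, which gives 450 nM
Compound 3, `CN(C)CCn1cnnc1-c1cc(Oc2ccc(NC(=O)N/N=C/c3ccc(F)cc3F)cc2F)ccn1`, which gives 960 nM

Among these three numbers, compound 3 stands second highest. Its nearest neighbour is compound 1, and the step of a 1.9-fold lower number from compound 1 to compound 3 (0.27 log units; within the scatter) stays within the scatter. Its furthest neighbour is compound 2, and the step of a 2.1-fold higher number from compound 2 to compound 3 (0.33 log units; beyond the scatter) lies beyond the scatter, though only modestly.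

Compound 4, `COc1cc(/C=N/NC(=O)Nc2ccc(Oc3ccnc(-c4nncn4CCN(C)C)c3)c(F)c2)cc(OC)c1OC`, differs from compound 3 by 3,4,5-trimethoxyphenyl in place of 2,4-difluorophenyl on a carbon with a double bond to nitrogen. The three measured steps all exchange the aryl group on this same carbon, so each bears on the change. The step of a 4.0-fold lower number from compound 1 to compound 2 (0.60 log units; beyond the scatter) was the largest; the step of a 1.9-fold lower number from compound 1 to compound 3 (0.27 log units; within the scatter), which removes two methoxy groups, made no difference beyond the scatter. Restoring methoxy groups is therefore expected to move the number little, if at all, in this assay.

Compound 4 is expected to give 1400 nM, with a likely range from 500 nM to 4000 nM. The estimated step of a 1.5-fold higher number from compound 3 to compound 4 (0.16 log units; within the scatter) is expected to remain within the scatter.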

Compound 4, half-maximal inhibitory concentration: 3620 nM
Estimate against measurement, compound 4: 2.6-fold (0.41 log units) below; low and high end bracket the measured number.
By their numbers in this assay, from the lowest: compound 2; then compounds 3 and 1 (each within the scatter of the next); then compound 4.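

In this assay, the aryl group on the carbon with a double bond to nitrogen can weaken as well as strengthen: 3,4,5-trimethoxyphenyl gives a 3.8-fold higher number from compound 3 to compound 4 (0.58 log units; beyond the scatter) and a 2.0-fold higher number from compound 1 to compound 4 (0.31 log units; beyond the scatter), which leaves compound 4 the weakest of the four. The widest gap at this position now separates it from the 3-bromo-4-hydroxyphenyl group, with an 8.0-fold higher number from compound 2 to compound 4 (0.91 log units; beyond the scatter), so the choice of aryl group matters more than compounds 1, 2 and 3 alone showed. No measurement at hand accounts for this change.

Bromine and hydroxyl occur only together in compound 2, so what each contributes on its own remains open. It is also unknown how an aryl group carrying an amine or a carboxylic acid would behave at this position.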